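Removing one chloro from a dichlorinated core

This account rests on a few compounds, and the source may have more. Where it says the series, first, only, none or still open, it means among the compounds named here.

Measured compounds:
- Compound 1 `ClCc1ccc(Cn2cnc3c(Cl)ncnc32)cc1`: in a functional assay on SW-620 cells (Homo sapiens) for cytotoxicity, read by sulforhodamine B assay, with a stated time of 48 h (on this read-out higher numbers stand for lower toxicity in this test and lower numbers for higher toxicity in this test), "not determined" (no result reported)
- Compound 2 `ClCc1cccc(Cn2cnc3nc(Cl)nc(Cl)c32)c1`: 4070 nM
- Compound 3 `Nc1nc(Cl)c2ncn(Cc3cccc(CCl)c3)c2n1`: 57500 nM

Among the measured compounds shown here, only two compounds carry a number here. Compound 2 gives 4070 nM, the lowest of the two numbers, so it is the more toxic of the pair in this assay. Where compound 2 carries one of its chloro groups, compound 3 carries an amino group, and compound 3 gives 57500 nM; the gap between the two is beyond the scatter.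

The next compound, compound 4 `ClCc1cccc(Cn2cnc3ncnc(Cl)c32)c1`, has not been tested. It is reached from compound 2 by a single change: hydrogen in place of chloro on an aromatic carbon. For the measured compounds named here, no pair of measured compounds shows this exact step, so the size of the effect has to be judged from what the two numbers show. Going by the values given here, the only comparison at hand, compound 2 against compound 3, indicates that changing the chloro at this position weakens the effect in this assay.

On that basis compound 4 is expected to be somewhat less toxic than compound 2, by a step of a 2.5-fold higher number from compound 2 to compound 4 (0.39 log units; beyond the scatter), modest but likely beyond the scatter. The estimate for compound 4 is 10000 nM, with a range from 3000 nM to 40000 nM.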

Compound 4, concentration lethal to 50% of the cells: 7410 nM
Estimate against measurement, compound 4: 1.3-fold (0.13 log units) above; the range from low to high includes it.
By their numbers in this assay, from the lowest: compounds 2 and 4 (each within the scatter of the next); then compound 3.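

In this assay, the chloro group between two ring nitrogen atoms gives way to hydrogen with a result that stays within the usual scatter: a 1.8-fold higher number from compound 2 to compound 4 (0.26 log units; within the scatter). This chloro is therefore not required for the toxicity seen with compound 2 in this test, and the much higher number of compound 3, at 57500 nM, cannot be read simply as the loss of that chloro, since compound 4 lacks it as well and gives 7410 nM; the high number goes with the amino group at this place, not with the absence of chloro. Nothing available explains why chloro and hydrogen read alike here.

On these data alone, only chloro, hydrogen and amino are seen at this position, so it remains open whether a methyl group, a methoxy group or a dimethylamino group would read like hydrogen or like amino. The other chloro group on the core and the chloromethyl group are present in every compound shown, so what replacing either one, for example the chloromethyl group with a hydroxymethyl group, would do also remains open.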